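Adding a methyl group to compound 1

A few compounds are considered here, and "the series" means these few. Any claim that something is new, unique, unknown or untested is made for them only; others in the source may bear on it.

Within the data shown here, in an ADME assay on microsomes from liver (Mus musculus) for metabolic stability, read by LC-MS, using NADPH, with a stated time of 10 min, tested at 0.5 uM (a higher number here means that more of the compound is left, a lower number that less of the compound is left), compound 1 `COC(=O)Nc1cc(-c2ccc(OC[C@@](C)(N)CC(C)C)nc2)ccn1` gives 79%, the higher of the two numbers measured so far. Among the measured compounds shown here, the only other measured compound, compound 2 `COC(=O)Nc1cc(-c2cnc(OC[C@@](C)(N)CC(C)C)c(OC)c2)ccn1`, gives 59%. The unmeasured compound 3 `COC(=O)Nc1cc(-c2cnc(OC[C@@](C)(N)CC(C)C)cc2C)ccn1` differs from compound 1 by methyl in place of hydrogen on an aromatic carbon, ortho to a large group and opposite the ring nitrogen. One measured step offers a guide, a number 20 percentage points lower from compound 1 to compound 2 (beyond the scatter), a modest change that comes with methoxy in place of hydrogen on an aromatic carbon. That is a different group at a different place, so it is only a loose guide. A step in the same direction is expected in this assay, probably a smaller one. The expected step is a number 11 percentage points lower from compound 1 to compound 3 (beyond the scatter). The estimate for compound 3 is 68%, with an expected range of 50% to 84%.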

Compound 3, percent of the compound remaining: 69%
Estimate against measurement, compound 3: 1 percentage points below; the range from low to high includes it.
By their numbers in this assay, from the lowest: compounds 2, 3 and 1 (each within the scatter of the next, the first and the last beyond it).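

Methyl in place of hydrogen on this aromatic carbon, ortho to a large group and opposite the ring nitrogen, gives a number 10 percentage points lower from compound 1 to compound 3 (within the scatter) in this assay. Among these compounds, this is the first reading for this position: a single added carbon here leaves the number inside the usual spread of repeated measurements, which the methoxy step, made at a different place, could not show. Nothing measured here bears on why the number stays within that spread.

As far as these compounds go, whether a larger group on the same carbon, such as ethyl or trifluoromethyl, would also stay within the scatter remains open. So does the result for a methoxy group or a chlorine atom at this position, so one methyl step cannot yet show how much this position tolerates.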